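Compound 4: 4-ethylpiperazin-1-yl added to compound 2

The source may report more compounds than this note shows. Statements on the series, on what has been measured and on what is new or still open speak of the compounds shown alone.

Measured in a functional assay on Jurkat cells (Homo sapiens) for inhibition, read by CCK-8 assay, with a stated time of 48 h; on this read-out higher numbers stand for weaker inhibition of growth and lower numbers for stronger inhibition of growth:
- compound 1 `Cc1ccccc1Nc1nc(NCc2ccccc2)ncc1Cl`: > 100000 nM, a limit of the assay
- compound 2 `Cc1ccccc1Nc1nc(Nc2ccccn2)ncc1Cl`: 20100 nM
- compound 3 `Cc1ccccc1Nc1nc(Nc2cc(Cl)ccn2)ncc1Cl`: 39600 nM

Within the data shown here, compound 2 and compound 3 carry the only exact numbers so far, and they lie within the scatter of each other: a 2.0-fold higher number from compound 2 to compound 3 (0.29 log units; within the scatter). Compound 1 stands only as a limit.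

Compound 4 `CCN1CCN(c2ccc(Nc3ncc(Cl)c(Nc4ccccc4C)n3)nc2)CC1` is compound 2 with 4-ethylpiperazin-1-yl in place of hydrogen on an aromatic carbon of the six-membered aromatic ring with 1 nitrogen: 4-ethylpiperazin-1-yl in place of hydrogen on an aromatic carbon. Among the measured compounds shown here, the chloro step above is the only measured change on that ring, but a different group enters here, so it sets no firm size. The other two steps, an at least 4.9-fold lower number from compound 1 to compound 2 (0.69 log units; beyond the scatter) and an at least 2.5-fold lower number from compound 1 to compound 3 (0.40 log units; beyond the scatter), replace benzyl on the nitrogen and show that this part of the molecule can move the number beyond the scatter. Both start from the limit of compound 1, so their full size is open.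

On that basis, a moderate move in this assay towards stronger inhibition is expected, though the direction is far from certain. The expected step is a 3.4-fold lower number from compound 2 to compound 4 (0.53 log units; beyond the scatter). Compound 4 is estimated at 6000 nM, with an expected range from 1000 nM to 30000 nM.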

Compound 4, concentration for 50% growth inhibition: > 100000 nM
Compound 4 ended at the assay's limit (the forecaster's own chance of this, stated with the estimate: 5%); at least 16-fold (1.22 log units) between middle value and limit.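

In this assay, the aromatic carbon two atoms from the ring nitrogen and para to a large group proves sensitive to substitution: 4-ethylpiperazin-1-yl in place of hydrogen gives an at least 4.9-fold higher number from compound 2 to compound 4 (0.69 log units; beyond the scatter). Among these compounds, this is the first change on this ring that moves the number beyond the scatter, whereas the chloro change on the same ring gives a 2.0-fold higher number from compound 2 to compound 3 (0.29 log units; within the scatter), and the direction here is towards weaker inhibition of growth. Compound 4 gives > 100000 nM, which is a limit of the assay, so the step has a lower bound but no measured full size, and this series offers little room to resolve such losses: the limit of > 100000 nM in this assay, at which 2 of the 4 values shown sit.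

The compounds shown leave open whether the loss belongs to the whole 4-ethylpiperazin-1-yl group or to its ethyl part, a question that an unsubstituted piperazine, a morpholine or a small open-chain amine such as dimethylamino at this carbon would address. Also open, as far as these compounds go, is whether a small group such as methyl or methoxy is accepted at this carbon, keeping the number close to that of compound 2.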